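Methyl for Bromo: Expecting the Next Value

The source may report more compounds than this note shows. Statements on the series, on what has been measured and on what is new or still open speak of the compounds shown alone.

Of the compounds shown here, three have been tested in a functional assay on CHO cells for antagonist activity at prostaglandin E2 receptor EP3 subtype (Homo sapiens), read by FLIPR, with a stated time of 1 h; a lower number here means a stronger inhibitor, a higher number a weaker inhibitor. Compound 1 `CN1C(=O)OC(C)(c2ccc(-c3ccc4ccccc4c3)[nH]c2=O)C1=O` gives 501 nM. Compound 2 `CC(C)C1(c2cc(Cl)c(-c3ccc4ccccc4c3)[nH]c2=O)OC(=O)NC1=O` gives 50.1 nM, and compound 3 `CC(C)C1(c2cc(Br)c(-c3ccc4ccccc4c3)[nH]c2=O)OC(=O)NC1=O` gives 39.8 nM. Compound 3 therefore sits at the low end of the three numbers: its value and that of compound 2 lie within the scatter of each other, while compound 1 sits far above both. For the measured compounds named here, the only single-point step measured, a 1.3-fold lower number from compound 2 to compound 3 (0.10 log units; within the scatter), exchanges one halogen for another and is small. Compound 4 `Cc1cc(C2(C(C)C)OC(=O)NC2=O)c(=O)[nH]c1-c1ccc2ccccc2c1` differs from compound 3 by methyl in place of bromo on an aromatic carbon. Going by the values given here, no measured step replaces a halogen with a carbon group, and both groups count one heavy atom, so the expectation rests on that small halogen swap. Compound 4 is expected to give 60 nM, with a range from 20 nM to 200 nM. That would mean an expected 1.5-fold higher number from compound 3 to compound 4 (0.18 log units; within the scatter).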

Compound 4, inhibition constant: 6.31 nM
The estimate for compound 4 lay 9.5-fold (0.98 log units) above the measured number; measured number below the stated range.
By their numbers in this assay, from the lowest: compound 4; then compounds 3 and 2 (each within the scatter of the next); then compound 1.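

In this assay, this position on the shared core turns out to respond to the group placed there: methyl in place of bromo gives a 6.3-fold lower number from compound 3 to compound 4 (0.80 log units; beyond the scatter), and methyl in place of chloro gives a 7.9-fold lower number from compound 2 to compound 4 (0.90 log units; beyond the scatter), whereas exchanging one halogen for the other gave only a 1.3-fold lower number from compound 2 to compound 3 (0.10 log units; within the scatter). Each of these groups counts one heavy atom, so a change of atom type alone, with no change in that count, can shift the number beyond the scatter. Nothing available here accounts for the gap between methyl and the halogens.

As far as these compounds go, whether a longer chain such as ethyl, or an amine, would give a lower or higher number than methyl at this position stays open.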